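Shifting the nitrophenyl group: working notes on compound 3

The source may hold more compounds than are shown below. What is called first, only, known or untested is meant among the compounds shown, and "the series" means these compounds.

compound 1 `C[C@H]1CC[C@@H]2[C@@H](OC(=O)[C@]23CC(c2ccc(N(C)C)cc2)=NO3)[C@]2(C)C(=O)C=C[C@@]12O`: 6300 nM
compound 2 `C[C@H]1CC[C@@H]2[C@@H](OC(=O)[C@]23CC(c2ccccc2[N+](=O)[O-])=NO3)[C@]2(C)C(=O)C=C[C@@]12O`: 37000 nM

Both values come from a functional assay on PC-3 cells (Homo sapiens) for cytotoxicity, read by sulforhodamine B assay, with a stated time of 48 h; a lower number here means a stronger inhibitor, a higher number a weaker inhibitor. Compound 2 stands at the higher of the two numbers, which makes it the weaker inhibitor of this pair. The gap is a 5.9-fold higher number from compound 1 to compound 2 (0.77 log units; beyond the scatter).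

Compound 3 `C[C@H]1CC[C@@H]2[C@@H](OC(=O)[C@]23CC(c2ccc([N+](=O)[O-])cc2)=NO3)[C@]2(C)C(=O)C=C[C@@]12O` has not been measured. It carries 4-nitrophenyl in place of 2-nitrophenyl on a carbon with a double bond to nitrogen. Among the compounds with values here, only the single measured step bears on this change, and only in part, since it replaces the nitro-bearing group with 4-(dimethylamino)phenyl rather than moving the nitro group. Within the data shown here, no measured pair isolates that move. Compound 3 does share the 4-substituted phenyl naming pattern with compound 1, which gives 6300 nM, so a modest shift towards that lower number is expected, smaller than the measured step. The expected change is a 2.3-fold lower number from compound 2 to compound 3 (0.36 log units; beyond the scatter). The estimate for compound 3 is 16000 nM, with an expected range of 6000 nM to 40000 nM.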

Compound 3, half-maximal inhibitory concentration: 12000 nM
The estimate for compound 3 lay 1.3-fold (0.12 log units) above the measured number; measured number inside the range.
By their numbers in this assay, from the lowest: compounds 1 and 3 (each within the scatter of the next); then compound 2.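

In this assay, moving the nitro group alone gives a 3.1-fold lower number from compound 2 to compound 3 (0.49 log units; beyond the scatter) on the phenyl ring attached to the carbon with a double bond to nitrogen of the five-membered ring. Compound 2 and compound 3 have the same atoms, joined differently. The exchange of groups with the 4-substitution kept gives a 1.9-fold higher number from compound 1 to compound 3 (0.28 log units; within the scatter), which leaves 4-nitrophenyl and 4-(dimethylamino)phenyl unseparated and indicates that the earlier step from compound 1 to compound 2 cannot be read simply as a replacement of dimethylamino by nitro. No measured evidence accounts for the difference between 2-nitrophenyl and 4-nitrophenyl.

From the compounds shown here alone, it remains open whether the gap between the 2-substituted and 4-substituted forms is particular to nitro or would recur with a group such as methoxy or a carboxylic acid on the same ring. Also open, going by these compounds, is how unsubstituted phenyl, or a phenyl carrying a primary amine, would stand against compound 1 and compound 3 in this assay.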